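The source may hold more compounds than are shown below. What is called first, only, known or untested is meant among the compounds shown, and "the series" means these compounds.

Compound 1 `O=c1[nH]c(=O)n([C@H]2C[C@H](O)[C@@H](CO)O2)cc1/C=C/I` — 63900 nM
Compound 2 `O=C(CI)NCc1cn([C@H]2C[C@H](O)[C@@H](CO)O2)c(=O)[nH]c1=O` — 107000 nM
Compound 3 `CS(=O)(=O)Cc1cn([C@H]2C[C@H](O)[C@@H](CO)O2)c(=O)[nH]c1=O` — > 200000 nM

In an ADME assay on L1210/0 cells (Mus musculus) for cytotoxicity, with a stated time of 48 h (a higher number here means a weaker inhibitor, a lower number a stronger inhibitor), compound 1 gives 63900 nM and compound 2 gives 107000 nM. For compound 3 this assay reports only a limit, > 200000 nM, so compound 3 stands at the weak edge of what is shown (the limit of > 200000 nM in this assay, at which 1 of the 3 values shown sits). The steps run a 1.7-fold higher number from compound 1 to compound 2 (0.22 log units; within the scatter), an at least 3.1-fold higher number from compound 1 to compound 3 (0.49 log units; beyond the scatter) and an at least 1.8-fold higher number from compound 2 to compound 3 (0.27 log units; that floor lies within the scatter); the step from compound 1 lies beyond the scatter, the others within it. Compound 4 `CCCCCC#Cc1cn([C@H]2C[C@H](O)[C@@H](CO)O2)c(=O)[nH]c1=O` differs from compound 3 thus: hept-1-yn-1-yl in place of (methylsulfonyl)methyl on an aromatic carbon. Among the compounds with values here, no measured step involves hept-1-yn-1-yl, yet the (methylsulfonyl)methyl group sits at the limit, so in this assay compound 4 is expected to return into the measurable range by an at least 4.0-fold lower number from compound 3 to compound 4 (0.60 log units; beyond the scatter). The estimate for compound 4 is 50000 nM, between 8000 nM and 200000 nM.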

Compound 4, half-maximal inhibitory concentration: > 200000 nM
Compound 4 ended at the assay's limit; the forecaster's own chance of this, stated with the estimate: 30%; at least 4.0-fold (0.60 log units) between middle value and limit.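

In this assay compound 4 gives > 200000 nM, which is a limit of the assay and not a number. This position thus reaches the limit with an all-carbon hept-1-yn-1-yl group as well as with (methylsulfonyl)methyl, and the step between those two limits cannot be read: the limit of > 200000 nM in this assay, at which 2 of the 4 values shown sit. Hept-1-yn-1-yl in place of 2-iodoethenyl gives an at least 3.1-fold higher number from compound 1 to compound 4 (0.49 log units; beyond the scatter), while in place of (((iodomethyl)carbonyl)amino)methyl it gives an at least 1.8-fold higher number from compound 2 to compound 4 (0.27 log units; that floor lies within the scatter). The compounds shown leave open whether a shorter alkynyl chain, an amine or a carboxylic acid at this position would give a value within the measurable range.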